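Cytotoxicity on dog kidney cells: from cyclopropyl to isobutyl

A few compounds are considered here, and "the series" means these few. Any claim that something is new, unique, unknown or untested is made for them only; others in the source may bear on it.

Two compounds share the same bicyclic amine core, each carrying a five-membered aromatic ring with two nitrogen atoms joined through a methylene-amine link. Compound 1 is `CCc1nc[nH]c1CN[C@@H]1C[C@@H]2C[C@H]([C@H]1C)C2(C)C` and compound 2 is `C[C@@H]1[C@H]2C[C@@H](C[C@H]1NCc1cnc(C3CC3)[nH]1)C2(C)C`. In an ADME assay on MDCK cells (Canis lupus familiaris) for cytotoxicity, read by MTT assay, with a stated time of 48 h (a lower number here means that less compound is tolerated, a higher number that more compound is tolerated), compound 1 gives 180000 nM. In this assay compound 2 gives 94500 nM. Compound 2 thus stands at the lower of the two numbers, but its gap to compound 1 lies within the scatter of repeated measurements, so the two cannot be ranked against each other.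

Compound 3 is `CC(C)Cc1ncc(CN[C@@H]2C[C@@H]3C[C@H]([C@H]2C)C3(C)C)[nH]1`. It differs from compound 2 in one place: isobutyl in place of cyclopropyl on an aromatic carbon. Among the compounds with values here, no measured pair in this set shows the effect of such a change, so there is no step to lean on. The expectation is that the step from compound 2 to compound 3 will be small, with no clear direction beyond the scatter, which is what a 1.1-fold lower number from compound 2 to compound 3 (0.05 log units; within the scatter) expresses. On that basis compound 3 is estimated to give 85000 nM in this assay, with a likely range from 35000 nM to 200000 nM.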

Compound 3, half-maximal cytotoxic concentration: 74800 nM
Beside the measured number, compound 3's estimate is 1.1-fold (0.06 log units) above it; the range from low to high includes it.
By their numbers in this assay, from the lowest: compounds 3, 2 and 1 (each within the scatter of the next, the first and the last beyond it).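

Within the data shown here, this is the first comparison in the set where only one place differs, so it is the first direct look at a change at this position, on an aromatic carbon between two ring nitrogen atoms. In this assay, the swap of cyclopropyl for isobutyl gives a 1.3-fold lower number from compound 2 to compound 3 (0.10 log units; within the scatter). A closed three-membered ring of carbon gives way here to an open, branched group with one more carbon, and even so, this one pair shows no difference that can be told apart from the scatter of repeated measurements. Nothing in the available data explains the size of this step.

Cyclopropyl and isobutyl are both made of carbon and hydrogen alone and carry no hydrogen-bond donors or acceptors, so this single pair says nothing about how the cells would tolerate a group of another kind at this position. How an amine, a carboxylic acid or a much longer carbon chain in that place would read in this assay remains an open question.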